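Shortening the linker to a benzoic acid in compound 3

The source may hold more compounds than are shown below. What is called first, only, known or untested is meant among the compounds shown, and "the series" means these compounds.

Compound 3 `Cc1c(OCCCCOCOc2ccc(C(=O)O)cc2)ccc(C(=O)CC2CCCC2)c1O` is the strongest of the three measured compounds in an assay on HEK293 cells for positive allosteric modulation of metabotropic glutamate receptor 3 (Rattus norvegicus), read by thallium flux, with a stated time of 2.5 min (on this read-out lower numbers stand for smaller maximal responses and higher numbers for larger maximal responses), where compound 3 gives 46.9%. The other two sit well beneath it: compound 1 `COc1cc(C(=O)O)ccc1OCCCCOc1ccc(C(=O)C(C)C)c(O)c1C` gives 25.6%, and compound 2 `COC(=O)c1ccc(OCCCCOc2ccc(C(=O)CC3CCCC3)c(O)c2C)cc1` gives 22%, so compound 3 stands above both by gaps beyond the scatter.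

The next compound, compound 4 `Cc1c(OCCCCOc2ccccc2C(=O)O)ccc(C(=O)CC2CCCC2)c1O`, changes the end of the chain: 2-carboxyphenyl in place of (4-carboxyphenoxy)methyl on an oxygen on a saturated carbon. For the measured compounds named here, one measured step touches the same place. Going a number 24.9 percentage points higher from compound 2 to compound 3 (beyond the scatter) shows that lengthening the chain by an oxygen-bearing carbon and swapping the ester for an acid raised the maximal response modestly. Compound 4 undoes the lengthening while keeping an acid, so it resembles compound 1 and compound 2 in chain length, and both of those gave low responses. Going by the values given here, no step separates the effect of chain length from that of the acid, and no measured compound carries a 2-carboxyphenyl group, so the outlook is uncertain.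

On balance compound 4 is expected to fall back toward the lower responses, with the step of a number 16.9 percentage points lower from compound 3 to compound 4 (beyond the scatter) expected. The estimate for compound 4 is 30%, within 18% to 45%.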

Compound 4, largest response reached (reported as percent of maximum), in percent of the reference or control that the assay uses: 32.9%
Compound 4: middle estimate off by 2.9 percentage points, on the low side, within the range that was stated.
By their numbers in this assay, from the lowest: compounds 2, 1 and 4 (each within the scatter of the next, the first and the last beyond it); then compound 3.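

In this assay the end group on the oxygen on a saturated carbon moves the response in both directions: 2-carboxyphenyl gives a number 14 percentage points lower from compound 3 to compound 4 (beyond the scatter) and also a number 10.9 percentage points higher from compound 2 to compound 4 (beyond the scatter). A free carboxylic acid at the end of the chain is therefore not enough on its own to reach the level of compound 3, since compound 3 and compound 4 both carry one and still stand apart. The gain over compound 2 cannot be credited to the acid alone either, as the swap from 4-(methoxycarbonyl)phenyl to 2-carboxyphenyl alters more than the ester, and nothing measured here gives a reason for either step.

The compounds shown leave open how much of the difference between compound 3 and compound 4 comes from the (4-carboxyphenoxy)methyl group as a whole and how much from where the acid sits, a question that a 4-carboxyphenyl group on the same oxygen would help to settle. They also leave open whether a primary amide or a tetrazole could take the place of the carboxylic acid in this position.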